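This account rests on a few compounds, and the source may have more. Where it says the series, first, only, none or still open, it means among the compounds named here.

Compound 1 `O=C(O)c1cnc2n(c1=O)CCC/C2=N\Nc1ccccc1` and compound 2 `CC1CC/C(=N\Nc2cccc(Br)c2)c2ncc(C(=O)O)c(=O)n21` were both tested in a functional assay on the whole organism for inhibition, with Rattus norvegicus as the target; on this read-out lower numbers stand for an effect already at smaller amounts and higher numbers for an effect only at larger amounts of compound. In this assay compound 1 reaches only a limit, > 100 umol/kg, as recorded in the limit of > 100 umol/kg in this assay, at which 1 of the 2 values shown sits. In this assay compound 2 likewise gives only a limit, > 320 umol/kg, recorded in the limit of > 320 umol/kg in this assay, at which 1 of the 2 values shown sits, so compound 2 stands at a limit, not at a number. Compound 3 `COc1ccc(N/N=C2\CCC(C)n3c2ncc(C(=O)O)c3=O)cc1` differs from compound 2 by 4-methoxyphenyl in place of 3-bromophenyl on an amine nitrogen. Going by the values given here, no step between two measured compounds is known here. The expected step is a number no higher from compound 2 to compound 3 (the limit leaves the size open), none beyond the scatter. Compound 3 is therefore expected to give 320 umol/kg, within a range from 100 umol/kg to 1000 umol/kg.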

Compound 3, dose for 50% inhibition: 7.6 umol/kg
For compound 3 the middle estimate is 42-fold (1.62 log units) above the measured one; the measured number lies below the stated range.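

The group on an amine nitrogen strongly shapes the result in this assay: 4-methoxyphenyl in place of 3-bromophenyl gives an at least 42-fold lower number from compound 2 to compound 3 (1.62 log units; beyond the scatter). Of the compounds shown, only compound 3 gives a number rather than a limit. Compound 2 gives only a limit, so the step may be larger still: the limit of > 320 umol/kg in this assay, at which 1 of the 3 values shown sits.

This single change alters both the group on the phenyl ring and its place on that ring, and the compounds shown do not separate the two. Going by these compounds, the values of 4-bromophenyl and 3-methoxyphenyl at this position remain open.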